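Aryl ether chain variation in a cytotoxicity series

The source may report more compounds than this note shows. Statements on the series, on what has been measured and on what is new or still open speak of the compounds shown alone.

compound 1 `CN(C)CCNc1ccnc2cc(OCc3ccccc3)ccc12`: 1250 nM
compound 2 `CCCCCCOc1ccc2c(Cl)ccnc2c1`: 2380 nM
compound 3 `C=CCOc1ccc2c(NCCN(C)C)ccnc2c1`: 1360 nM

In a functional assay on BGC-823 cells (Homo sapiens) for cytotoxicity, read by MTT assay, with a stated time of 48 h (a higher number here means a weaker inhibitor, a lower number a stronger inhibitor), compound 3 stands second highest of the three numbers, with compound 1 nearest and compound 2 furthest, both gaps within the scatter. Compound 4 `CCCCCCOc1ccc2c(NCCN(C)C)ccnc2c1` differs from compound 3 by pentyl in place of vinyl on a saturated chain carbon bound to an oxygen on an aromatic ring. Within the data shown here, the only measured step at this place is a 1.1-fold higher number from compound 1 to compound 3 (0.04 log units; within the scatter), which stayed within the scatter. Compound 2 also carries the hexyloxy group but differs from compound 4 elsewhere on the core, and compound 2 gives 2380 nM, again close to the others. No step beyond the scatter is therefore expected, with compound 4 expected to show a 1.1-fold higher number from compound 3 to compound 4 (0.04 log units; within the scatter). Compound 4 is estimated at 1500 nM, within 600 nM to 3800 nM.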

Compound 4, half-maximal inhibitory concentration: 1090 nM
Estimate against measurement, compound 4: 1.4-fold (0.14 log units) above; measured number inside the range.
By their numbers in this assay, from the lowest: compounds 4, 1, 3 and 2 (each within the scatter of the next, the first and the last beyond it).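

In this assay, pentyl in place of vinyl on a saturated chain carbon bound to an oxygen on an aromatic ring gives a 1.2-fold lower number from compound 3 to compound 4 (0.10 log units; within the scatter), and pentyl in place of phenyl gives a 1.1-fold lower number from compound 1 to compound 4 (0.06 log units; within the scatter). Vinyl, phenyl and pentyl at this place therefore remain within the scatter of one another. The only step shown beyond the scatter lies elsewhere: (2-(dimethylamino)ethyl)amino in place of chloro on an aromatic carbon gives a 2.2-fold lower number from compound 2 to compound 4 (0.34 log units; beyond the scatter), a modest change.

As far as these compounds go, whether a chain longer than hexyl or a terminal carboxylic acid on the chain would separate from these values remains open. Nothing available explains either result.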